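From a fluorophenyl to a chlorophenyl: an expected binding value

A few compounds are considered here, and "the series" means these few. Any claim that something is new, unique, unknown or untested is made for them only; others in the source may bear on it.

Measured compounds:
compound 1 `O=C(O)Cc1sc(C(c2ccc(F)cc2)c2ccc(F)cc2)nc1-c1cc(F)cc(F)c1` gives 35 nM in an in vitro assay on HEK385-7 cells for displacement of a labelled ligand from prostaglandin D2 receptor 2 (Homo sapiens); a higher number here means a weaker inhibitor, a lower number a stronger inhibitor;
compound 2 `O=C(O)Cc1sc(C(c2ccc(F)cc2)c2ccc(F)cc2)nc1-c1ccnc(N2CCCC2)c1` gives 230 nM;
compound 3 `O=C(O)Cc1sc(C(c2ccc(F)cc2)c2ccc(F)cc2)nc1-c1cccc(F)c1` gives 1.4 nM.

Compound 3 stands lowest of the three numbers and is therefore the strongest inhibitor here, since the steps of a 25-fold lower number from compound 1 to compound 3 (1.40 log units; beyond the scatter) and a 160-fold lower number from compound 2 to compound 3 (2.22 log units; beyond the scatter) both lie beyond the scatter. Compound 4 `O=C(O)Cc1sc(C(c2ccc(F)cc2)c2ccc(F)cc2)nc1-c1ccc(Cl)cc1` differs from compound 3 by one change: 4-chlorophenyl in place of 3-fluorophenyl on an aromatic carbon. Among the compounds with values here, no measured step exchanges one halogen for another or moves a halogen to a different position on this ring; the steps from compound 1 and compound 2 show only that this ring is sensitive to change. A step of a 4.3-fold higher number from compound 3 to compound 4 (0.63 log units; beyond the scatter) is expected, towards a weaker inhibitor but with wide uncertainty. Compound 4 is estimated at 6 nM, within 1.5 nM to 30 nM.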

Compound 4, half-maximal inhibitory concentration: 9.7 nM
Compound 4: the middle estimate sits 1.6-fold (0.21 log units) below what was measured; the range from low to high includes it.
By their numbers in this assay, from the lowest: compound 3; then compound 4; then compound 1; then compound 2.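

Swapping 3-fluorophenyl for 4-chlorophenyl changes both the halogen and its place on the ring, and it costs only a modest amount of binding: a 6.9-fold higher number from compound 3 to compound 4 (0.84 log units; beyond the scatter). The new ring still does better than the other two, with a 3.6-fold lower number from compound 1 to compound 4 (0.56 log units; beyond the scatter) and a 24-fold lower number from compound 2 to compound 4 (1.37 log units; beyond the scatter). No evidence is available to explain these steps.

On these data alone, whether the loss comes from the halogen itself or from its place on the ring stays open. A 3-chlorophenyl or 4-fluorophenyl group, each changing only one of the two, would separate them.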